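Thiazolyl sulfonamide in place of bromophenyl: stability note

This account rests on a few compounds, and the source may have more. Where it says the series, first, only, none or still open, it means among the compounds named here.

Measured in an ADME assay on S9 fraction from liver (Mus musculus, strain ICR/CD-1) for metabolic stability, read by LC-MS, using NADPH, with a stated time of 5 min, tested at 2 uM; on this read-out higher numbers stand for a longer-lived compound and lower numbers for a shorter-lived compound:
compound 1 `CC1CCN(C2CCN(S(=O)(=O)c3ccccc3Br)CC2)CC1` gives 0.1 h
compound 2 `CC1CCN(C2CCN(S(=O)(=O)c3cc(Br)cc4c3OCC4)CC2)CC1` gives 0.0833 h
compound 3 `CC1CCN(C2CCN(S(=O)(=O)c3ccccc3-c3ccccc3)CC2)CC1` gives < 0.1 h, a limit of the assay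

Compound 1 and compound 2 lie within the scatter of each other, so no order between them can be read. Compound 3 gives only a limit, so the step of a number no higher from compound 1 to compound 3 (the limit leaves the size open) is of unreadable size. All three measured compounds are short-lived on this read-out.

Compound 4 `Cc1nc(Cl)sc1S(=O)(=O)N1CCC(N2CCC(C)CC2)CC1` differs from compound 1 by 2-chloro-4-methyl-1,3-thiazol-5-yl in place of 2-bromophenyl on a sulfonyl sulfur. Going by the values given here, no measured step exchanges the aromatic ring on the sulfonyl sulfur for a heteroaromatic one; the only measured change at that ring, phenyl for bromo, leaves compound 3 at the limit (the limit of < 0.1 h in this assay, at which 1 of the 3 values shown sits). With every measured compound short-lived, no step beyond the scatter is expected for compound 4 in this assay. Compound 4 is expected to give about 0.1 h, between 0.03 h and 0.3 h, an expected step of no change at the digits printed from compound 1 to compound 4 (within the scatter). A fair chance remains that the assay reports only a limit.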

Compound 4, half-life: 0.167 h
For compound 4 the middle estimate is 1.7-fold (0.22 log units) below the measured one; the measured number falls inside the stated range.
By their numbers in this assay, from the lowest: compounds 2, 1 and 4 (each within the scatter of the next).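

Exchanging 2-bromophenyl for 2-chloro-4-methyl-1,3-thiazol-5-yl on a sulfonyl sulfur gives, in this assay, a 1.7-fold higher number from compound 1 to compound 4 (0.22 log units; within the scatter). Compound 4 carries the only heteroaromatic ring among the compounds shown, and it returns a measured number rather than a limit. Its five-membered aromatic ring with 2 hetero atoms brings 2 hydrogen-bond acceptors where 2-bromophenyl has 0, yet the half-life shows no readable change, and the series stays short-lived on this read-out.

Going by these compounds, compound 3 gives only a limit, so its step cannot be read: the limit of < 0.1 h in this assay, at which 1 of the 4 values shown sits. Whether a pyridyl ring or a carboxylic acid on the sulfonyl-bound ring would move the half-life beyond the scatter remains open.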